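This account rests on a few compounds, and the source may have more. Where it says the series, first, only, none or still open, it means among the compounds named here.

Measured compounds:
compound 1, `COc1ccc(N2C(=O)N(Cc3ccc(F)cc3Cl)c3ccccc3S2(=O)=O)cc1OC`
compound 2, `COc1ccc(N2C(=O)N(Cc3c(F)cc(C)cc3Cl)c3ccccc3S2(=O)=O)cc1OC`

In an assay on isolated protein for displacement of a labelled ligand from Orexin/Hypocretin receptor type 1 (Homo sapiens), with a stated time of 90 min (a higher number here means a weaker inhibitor, a lower number a stronger inhibitor), compound 1 gives only a limit, > 2510 nM. In this assay compound 2 gives 6.31 nM, the only actual number shown. Compound 1 alone sits at the limit of > 2510 nM in this assay, at which 1 of the 2 values shown sits. Among the compounds with values here, the sole measured step, an at least 390-fold lower number from compound 1 to compound 2 (2.59 log units; beyond the scatter), is large. Compound 3, `COc1ccc(N2C(=O)N(Cc3ccccc3)c3ccccc3S2(=O)=O)cc1OC`, differs from compound 2 by phenyl in place of 2-chloro-6-fluoro-4-methylphenyl on a saturated chain carbon bound to an amide-type nitrogen in a ring, stripping the ring bare, further than the measured step went. A large step toward weaker binding is expected, a 240-fold higher number from compound 2 to compound 3 (2.38 log units; beyond the scatter). Compound 3 is therefore estimated at 1500 nM, range 200 nM to 10000 nM, with a fair chance of reaching only a limit.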

Compound 3, inhibition constant: 2000 nM
For compound 3 the middle estimate is 1.3-fold (0.12 log units) below the measured one, and the stated range covers the measured number.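

With phenyl on the saturated chain carbon, this assay gives a measured reference for the bare ring, and the step, a 320-fold higher number from compound 2 to compound 3 (2.50 log units; beyond the scatter), ties the strong binding of compound 2 to its 2-chloro-6-fluoro-4-methylphenyl. Between the 2-chloro-4-fluorophenyl and phenyl no order can be read: an at least 1.2-fold lower number from compound 1 to compound 3 (0.09 log units; that floor lies within the scatter). Compound 1 remains a limit: the limit of > 2510 nM in this assay, at which 1 of the 3 values shown sits.

Which substituent of the 2-chloro-6-fluoro-4-methylphenyl carries the gain, or whether it takes all of them together, stays open. From the compounds shown here alone, how a methoxy group or an amine on that ring would read is also open.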